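Swapping Fluorines for Methyls on the Weakest Analogue

This account rests on a few compounds, and the source may have more. Where it says the series, first, only, none or still open, it means among the compounds named here.

Compound 3 `COc1cc(-n2cnc3ccc(-c4cc(F)ccc4F)cc32)cc(OC)c1OC` gives 6420 nM in a functional assay on MCF7 cells (Homo sapiens) for antiproliferative activity, read by MTT assay, with a stated time of 72 h (on this read-out lower numbers stand for stronger inhibition and higher numbers for weaker inhibition), the highest number among the three compounds measured here. Compound 1 `COc1cc(-n2cnc3ccc(-c4cccc(N)c4)cc32)cc(OC)c1OC` gives 180 nM and compound 2 `COc1cc(-n2cnc3ccc(-c4ccc([N+](=O)[O-])cc4)cc32)cc(OC)c1OC` gives 740 nM; the steps toward compound 3 run a 36-fold higher number from compound 1 to compound 3 (1.55 log units; beyond the scatter) and an 8.7-fold higher number from compound 2 to compound 3 (0.94 log units; beyond the scatter). Compound 4 `COc1cc(-n2cnc3ccc(-c4cccc(C)c4C)cc32)cc(OC)c1OC` differs from compound 3 in one place: 2,3-dimethylphenyl in place of 2,5-difluorophenyl on an aromatic carbon. Within the data shown here, no measured step brings in a dimethylphenyl group of any kind, so the two steps above show only that compound 3 sits well behind its two neighbours. A modest move toward lower numbers seems the most plausible outcome, with wide uncertainty either way. Compound 4 is therefore expected at 2500 nM, between 600 nM and 10000 nM, which amounts to a 2.6-fold lower number from compound 3 to compound 4 (0.41 log units; beyond the scatter).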

Compound 4, half-maximal inhibitory concentration: 2150 nM
Beside the measured number, compound 4's estimate is 1.2-fold (0.07 log units) above it; low and high end bracket the measured number.
By their numbers in this assay, from the lowest: compound 1; then compound 2; then compound 4; then compound 3.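

In this assay, the 2,3-dimethylphenyl group improves on 2,5-difluorophenyl at this position, with a 3.0-fold lower number from compound 3 to compound 4 (0.48 log units; beyond the scatter) as the step, so the fluorines are not required for activity here. The gain remains small against the other groups: a 2.9-fold higher number from compound 2 to compound 4 (0.46 log units; beyond the scatter) separates it from 4-nitrophenyl, and a 12-fold higher number from compound 1 to compound 4 (1.08 log units; beyond the scatter) separates it from 3-aminophenyl. No measurement here explains these differences.

Going by these compounds, the swap changes both the kind of substituent and where it sits, so the effect of each alone remains unknown. A 2,5-dimethylphenyl group would separate the two, while a 3-hydroxyphenyl group would test how specific the 3-aminophenyl result is.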